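Thiophene attachment point in a 2,4,6-trisubstituted pyridine series

The compounds below may be only part of what the source reports. "The series", "measured", "known", "first", "only" and "open" are said of these compounds alone.

Three compounds in this set have a measured number in a functional assay on HCT-15 cells (Homo sapiens) for cytotoxicity, read by CCK-8 assay and cell counting, with a stated time of 2 days; on this read-out higher numbers stand for weaker inhibition and lower numbers for stronger inhibition. Compound 1 `Oc1ccc(-c2cc(-c3cccs3)nc(-c3ccccc3Cl)c2)cc1` gives 5430 nM in this assay. Compound 3 `Oc1ccc(-c2cc(-c3ccsc3)nc(-c3ccccc3Cl)c2)cc1` gives 5830 nM in this assay. Compound 2 `Oc1cccc(-c2cc(-c3ccsc3)nc(-c3cccc(Cl)c3)c2)c1` gives 2510 nM in this assay, the lowest of the three, and its steps to compound 1 and to compound 3 are both beyond the scatter. The difference between the core of compound 2 and the core of compound 3 is not broken down here.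

One structural change has a measured step. From compound 3 to compound 1 the change is thiophen-2-yl in place of thiophen-3-yl on an aromatic carbon, and it made a 1.1-fold lower number from compound 3 to compound 1 (0.03 log units; within the scatter). The same kind of change leads from compound 2 to the unmeasured compound 4 `Oc1cccc(-c2cc(-c3cccc(Cl)c3)nc(-c3cccs3)c2)c1`: thiophen-2-yl in place of thiophen-3-yl on an aromatic carbon. It is not the same change, since around the place the groups differ: for compound 3 the place is meta to a 2-chlorophenyl group and meta to a 4-hydroxyphenyl group, whereas for compound 2 it is meta to a 3-chlorophenyl group and meta to a 3-hydroxyphenyl group.

Because a 1.1-fold lower number from compound 3 to compound 1 (0.03 log units; within the scatter) lies within the scatter, the step from compound 2 to compound 4 is expected to be small as well, about a 1.0-fold lower number from compound 2 to compound 4 (0.02 log units; within the scatter) in this assay. Compound 4 is therefore estimated at 2400 nM in this assay, with a range from 1200 nM to 5000 nM that allows for the different surroundings of the place.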

Compound 4, half-maximal inhibitory concentration: 2610 nM
Beside the measured number, compound 4's estimate is 1.1-fold (0.04 log units) below it, and the stated range covers the measured number.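

In this assay, thiophen-2-yl in place of thiophen-3-yl on the core of compound 2 gives a 1.0-fold higher number from compound 2 to compound 4 (0.02 log units; within the scatter), so this pair cannot be told apart on this read-out. Set beside the earlier step, the change carries across the two cores without a readable difference: the same change on two cores in this assay, a 1.1-fold lower number (0.03 log units; within the scatter) from compound 3 to compound 1 and a 1.0-fold higher number (0.02 log units; within the scatter) from compound 2 to compound 4, 1.1-fold (0.05 log units) apart, within the scatter of two such steps. This shows that the thiophene attachment point makes no readable difference on these two cores in this one assay, but it does not show that the same would hold on other cores or in other assays, and agreement between two steps this small does not show that a larger step would carry over in the same way.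

The thiophene ring is present throughout the compounds shown, so it remains open how an amine, a carboxylic acid or a longer chain would read at the same place on the ring. The pairs shown also do not separate the 2-chlorophenyl and 3-chlorophenyl groups from the 4-hydroxyphenyl and 3-hydroxyphenyl groups, so the contribution of each to the number remains open.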